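A few compounds are considered here, and "the series" means these few. Any claim that something is new, unique, unknown or untested is made for them only; others in the source may bear on it.

Compound 2 `Cc1ccc(Nc2nc(Cl)nc3c2ncn3Cc2ccc(/C=C/C(=O)Nc3ccccc3N)cc2)cc1` gives 0.27% in a functional assay on HCT-116 cells (Homo sapiens) for antiproliferative activity, read by CCK-8 assay, with a stated time of 72 h, tested at 2 uM (a higher number here means a stronger effect of the compound at the concentration tested, a lower number a weaker effect), the lowest of the three numbers. Compound 1 `Cc1ccc(Nc2nc(Cl)nc3c2ncn3Cc2ccc(C(=O)Nc3ccccc3N)cc2)cc1` gives 76.3% and compound 3 `Nc1ccccc1NC(=O)c1ccc(Cn2cnc3c(NCc4ccccc4)nc(Cl)nc32)cc1` gives 68.3%; the change a number 76 percentage points lower from compound 1 to compound 2 (beyond the scatter) is large, whereas a number 8 percentage points lower from compound 1 to compound 3 (within the scatter) stays within the scatter. Compound 4 `Nc1ccccc1NC(=O)/C=C/c1ccc(Cn2cnc3c(Nc4cccc(OC(F)(F)F)c4)nc(Cl)nc32)cc1` keeps the linker of compound 2 and differs only at the nitrogen: 3-(trifluoromethoxy)phenyl in place of 4-methylphenyl on a nitrogen on an aromatic ring. Among the measured compounds shown here, the one measured step at that nitrogen, a number 8 percentage points lower from compound 1 to compound 3 (within the scatter), was within the scatter, and no step tests this change on the linker of compound 2. Compound 4 is therefore expected to stay close to compound 2, with a number 9.7 percentage points higher from compound 2 to compound 4 (within the scatter) estimated as no step beyond the scatter. Compound 4 is estimated at 10%, with a range from 0% to 40%.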

Compound 4, a percentage reported as inhibition, at one concentration (the size of the read-out at that concentration, not a potency): 2.8%
Beside the measured number, compound 4's estimate is 7.2 percentage points above it, within the range that was stated.
By their numbers in this assay, from the lowest: compounds 2 and 4 (each within the scatter of the next); then compounds 3 and 1 (each within the scatter of the next).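

Among the compounds shown here, the step of a number 2.5 percentage points higher from compound 2 to compound 4 (within the scatter) in this assay gives the first reading of a change at this nitrogen on the linker of compound 2. With that linker, 3-(trifluoromethoxy)phenyl and 4-methylphenyl give numbers within the scatter of each other, so the low number of compound 2 is not confined to 4-methylphenyl. No measured evidence here accounts for this result.

Still open, from the compounds shown here alone, is how 3-(trifluoromethoxy)phenyl behaves on the linker of compound 1. Also open, going by these compounds, is whether a benzyl group, a simple amine or a longer chain on this nitrogen would change the number on the linker of compound 2.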